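This account rests on a few compounds, and the source may have more. Where it says the series, first, only, none or still open, it means among the compounds named here.

- compound 1 `CCn1c([C@@H](C)NS(=O)(=O)c2ccc(C#N)cc2)nc2ccc(C(F)(F)F)cc21` gives 34 mL.min-1.g-1
- compound 2 `CCn1c([C@@H](C)NS(=O)(=O)c2c(F)cc(F)cc2F)nc2ccc(C(F)(F)F)cc21` gives 19 mL.min-1.g-1

Both numbers come from an ADME assay (liver) for metabolic stability, with Liver microsome (Homo sapiens) as the target, read by LC-MS, using microsomes and NADPH, with a stated time of 5 min, at 37 degrees C; on this read-out higher numbers stand for fast clearance and lower numbers for slow clearance. Repeated measurements of this kind scatter, and compound 2 at 19 mL.min-1.g-1 cannot be told apart from compound 1 on this read-out.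

The next compound, compound 3 `CCn1c([C@@H](C)NS(=O)(=O)c2cn(C)nc2C)nc2ccc(C(F)(F)F)cc21`, keeps the shared core and differs from compound 2 only in the group on the sulfonyl sulfur: 1,3-dimethyl-1H-pyrazol-4-yl in place of 2,4,6-trifluorophenyl on a sulfonyl sulfur. A six-membered aromatic ring of carbon only gives way to a five-membered aromatic ring with 2 hetero atoms.

Among the compounds with values here, only one measured step changes the group at this place, swapping 4-cyanophenyl for 2,4,6-trifluorophenyl. It is a 1.8-fold lower number from compound 1 to compound 2 (0.25 log units; within the scatter), so the group changed there without a step beyond the scatter. Neither measured compound carries a 1,3-dimethyl-1H-pyrazol-4-yl group, which makes this a weak guide, and it gives no firm direction. No step beyond the scatter is therefore expected in this assay.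

The expected step is a 1.3-fold higher number from compound 2 to compound 3 (0.10 log units; within the scatter), an estimate that stays within the scatter. The estimated value for compound 3 is 24 mL.min-1.g-1, with an expected range from 10 mL.min-1.g-1 to 55 mL.min-1.g-1.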

Compound 3, intrinsic clearance in microsomes: 28 mL.min-1.g-1
Compound 3: middle estimate off by 1.2-fold (0.07 log units), on the low side; the measured number falls inside the stated range.
By their numbers in this assay, from the lowest: compounds 2, 3 and 1 (each within the scatter of the next).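

Replacing the six-membered aromatic ring of carbon only in compound 2 with 1,3-dimethyl-1H-pyrazol-4-yl, a five-membered aromatic ring with 2 hetero atoms, gives no readable difference in this assay (a 1.5-fold higher number from compound 2 to compound 3 (0.17 log units; within the scatter)). The same holds when this group is set against the 4-cyanophenyl group of compound 1 (a 1.2-fold lower number from compound 1 to compound 3 (0.08 log units; within the scatter)), so three rings of different size and make-up on the sulfonyl sulfur now lie within the scatter of one another, even though the entering group has 2 hydrogen-bond acceptors and 2,4,6-trifluorophenyl has 0. No measurement at hand explains why these numbers lie so close together.

On these data alone, all three groups at this place are aromatic rings, so it remains open how this assay would respond to a plain alkyl chain such as n-butyl or a saturated ring such as piperidine on the sulfonyl sulfur. The ethyl and trifluoromethyl groups are the same in all three compounds, so these results also cannot show how much a change at either group would matter.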